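Compound 4: Cyclopentyl in Place of Methyl

The source may report more compounds than this note shows. Statements on the series, on what has been measured and on what is new or still open speak of the compounds shown alone.

Compound 1 (`CCNC(=O)Nc1sc2ccccc2c1C(=O)N1CCN(C2CCN(C(=O)CC)CC2)CC1`) – "not determined" (no result reported)
Compound 2 (`CCNC(=O)Nc1sc2ccccc2c1C(=O)N1CCN(C2CCN(C(=O)C3CCCCC3)CC2)CC1`) – 146 nM
Compound 3 (`CCNC(=O)Nc1sc2ccccc2c1C(=O)N1CCN(C2CCN(C(=O)OC)CC2)CC1`) – "not determined" (no result reported)

These three compounds share the same core and differ at one end of the structure. Going by the values given here, in a functional assay on HepG2 cells (Homo sapiens) for inhibition, read by scintillation counting, with a stated time of 2 h (on this read-out higher numbers stand for weaker inhibition and lower numbers for stronger inhibition), compound 2 gives 146 nM as the only number so far. Compound 3 has no place on this scale, since its entry reads "not determined" (no result reported) in this assay and compound 1 likewise has no single number.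

One change leads onward, cyclopentyl in place of methyl on an oxygen next to a carbonyl group with cyclopentyl in place of methyl on an oxygen next to a carbonyl group. The resulting structure is compound 4 (`CCNC(=O)Nc1sc2ccccc2c1C(=O)N1CCN(C2CCN(C(=O)OC3CCCC3)CC2)CC1`) and it has not yet been measured.

With no number for compound 3, the size of this step cannot be read from the data, and no direction can be expected with confidence. Among the compounds with values here, the one available guide is compound 2 at 146 nM so a result in that region is expected, with a wide margin. For compound 4 the estimated value is 140 nM with an expected range from 45 nM to 450 nM in this assay once measured.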

Compound 4, half-maximal inhibitory concentration: 512 nM
Estimate against measurement, compound 4: 3.7-fold (0.56 log units) below; the whole stated range lies below it.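

In this assay this end of the molecule now has a second number, and exchanging cyclohexyl on the carbonyl carbon for cyclopentyloxy gives a 3.5-fold higher number from compound 2 to compound 4 (0.54 log units; beyond the scatter) and so weaker inhibition. The group on this carbonyl carbon therefore affects the read-out, although this single exchange alters both the ring size and the presence of an oxygen, and the two changes cannot be separated here. Compound 3 has no number, so the step from methyl to cyclopentyl cannot be read, and nothing measured here explains the shift.

As far as these compounds go, it remains open whether cyclohexyloxy would behave more like cyclohexyl or like cyclopentyloxy, which would help separate ring size from the oxygen. From the compounds shown here alone, how an amine on this carbonyl carbon, or a longer chain on the oxygen, would read in this assay also remains open.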